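The source may hold more compounds than are shown below. What is called first, only, known or untested is meant among the compounds shown, and "the series" means these compounds.

Compound 1 `Clc1ccc(COc2ccccc2/C=C/C(/C=C/c2ccccn2)=N/Oc2ncnc3cc(Cl)ccc23)c(Cl)c1`: 91.8%
Compound 2 `Cc1cccc2ncnc(O/N=C(\C=C\c3ccccn3)/C=C/c3ccccc3OCc3ccc(Cl)cc3Cl)c12`: 93.9%
Compound 3 `Cc1cccc2ncnc(O/N=C(\C=C\c3ccccn3)/C=C/c3ccccc3OCc3ccc(Cl)cc3)c12`: 94.5%

All three were run in a functional assay on SMMC-7721 cells (Homo sapiens) for inhibition, read by MTT assay, with a stated time of 72 h, tested at 10 uM; a higher number here means a stronger effect of the compound at the concentration tested, a lower number a weaker effect. In this assay compound 1 gives 91.8%, compound 2 gives 93.9% and compound 3 gives 94.5%; the three numbers lie within the scatter of one another, so no order among them can be read.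

Compound 1 and compound 2 differ by 7-chloroquinazolin-4-yl in place of 5-methylquinazolin-4-yl on an oxygen; the resulting step is a number 2.1 percentage points lower from compound 2 to compound 1 (within the scatter).

Compound 4 `Clc1ccc(COc2ccccc2/C=C/C(/C=C/c2ccccn2)=N/Oc2ncnc3cc(Cl)ccc23)cc1` has not yet been measured in this assay. For the measured compounds named here, it differs from compound 3 by 7-chloroquinazolin-4-yl in place of 5-methylquinazolin-4-yl on an oxygen, which is the same change as the one from compound 2 to compound 1. The two starting cores are themselves close: compound 3 differs from compound 2 by hydrogen in place of chloro on an aromatic carbon, with a step of a number 0.6 percentage points higher from compound 2 to compound 3 (within the scatter).

For compound 4 the step is expected to be a number 1.5 percentage points lower from compound 3 to compound 4 (within the scatter), because the earlier instance of this change gave a number 2.1 percentage points lower from compound 2 to compound 1 (within the scatter) and compound 3 starts from 94.5%. Compound 4 is therefore estimated at 93%, expected between 87% and 97%.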

Compound 4, a percentage reported as inhibition, at one concentration (the size of the read-out at that concentration, not a potency): 94.8%
For compound 4 the middle estimate is 1.8 percentage points below the measured one, and the stated range covers the measured number.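

In this assay, 7-chloroquinazolin-4-yl in place of 5-methylquinazolin-4-yl on an oxygen gives a number 0.3 percentage points higher from compound 3 to compound 4 (within the scatter), and this step does not differ from its earlier instance: the same change on two cores in this assay, a number 2.1 percentage points lower (within the scatter) from compound 2 to compound 1 and a number 0.3 percentage points higher (within the scatter) from compound 3 to compound 4, 2.4 percentage points apart, within the scatter of two such steps

Hydrogen in place of chloro on an aromatic carbon gives a number 3 percentage points higher from compound 1 to compound 4 (within the scatter), and this step likewise does not differ from its earlier instance: the same change on two cores in this assay, a number 0.6 percentage points higher (within the scatter) from compound 2 to compound 3 and a number 3 percentage points higher (within the scatter) from compound 1 to compound 4, 2.4 percentage points apart, within the scatter of two such steps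

For the compounds shown here, each change therefore reads the same on both cores, but every step is within the scatter, so the agreement shows only that neither change has a detectable effect here at one test concentration, not that a real effect carries from core to core, and it gives no measure of potency.

Still open, on these data alone, is whether an amine or a carboxylic acid in place of the chloro, or a longer chain in place of the methyl of 5-methylquinazolin-4-yl, would move the read-out beyond the scatter. Also open, as far as these compounds go, is whether these four compounds would separate at lower concentrations.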